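A few compounds are considered here, and "the series" means these few. Any claim that something is new, unique, unknown or untested is made for them only; others in the source may bear on it.

Three compounds sharing one core have numbers in a functional assay on HeLa cells (Homo sapiens) for cytotoxicity, read by MTT assay, with a stated time of 24 h; a higher number here means a weaker inhibitor, a lower number a stronger inhibitor. Here compound 1 `COc1ccc(/C=C(\C#N)C(=O)N/N=C(\C)c2c(O)c3ccc(O)cc3oc2=O)cc1` gives 7850 nM and compound 3 `C/C(=N\NC(=O)/C(C#N)=C/c1ccc([N+](=O)[O-])cc1)c1c(O)c2ccc(O)cc2oc1=O` gives 8360 nM, and a 1.1-fold higher number from compound 1 to compound 3 (0.03 log units; within the scatter) leaves these two level. Compound 2 `C/C(=N\NC(=O)/C(C#N)=C/c1cccc([N+](=O)[O-])c1)c1c(O)c2ccc(O)cc2oc1=O` gives 24600 nM, so compound 1 shares the stronger end of this small set with compound 3, while a 3.1-fold higher number from compound 1 to compound 2 (0.50 log units; beyond the scatter) separates it from compound 2.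

Compound 4 `C/C(=N\NC(=O)/C(C#N)=C/c1ccccc1Cl)c1c(O)c2ccc(O)cc2oc1=O` has not yet been measured. Going by the values given here, its one change from compound 1 is 2-chlorophenyl in place of 4-methoxyphenyl on a double-bonded chain carbon bound to a double-bonded chain carbon.

The measured steps that bear on this change are those at the same place, on a double-bonded chain carbon bound to a double-bonded chain carbon. Replacing the 4-methoxyphenyl has so far produced two outcomes: no change beyond the scatter for compound 3, and a modest weakening for compound 2. The two nitrophenyl compounds also differ from each other, by a 2.9-fold lower number from compound 2 to compound 3 (0.47 log units; beyond the scatter). Among the compounds with values here, none of the measured compounds carries a 2-chlorophenyl, so these steps offer only a rough guide to size.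

A small weakening in this assay is therefore expected, most likely within the scatter and unlikely to exceed the modest step seen for compound 2. The expected step is a 1.4-fold higher number from compound 1 to compound 4 (0.15 log units; within the scatter). For compound 4 the estimated value is 11000 nM, with an expected range of 5000 nM to 25000 nM.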

Compound 4, half-maximal inhibitory concentration: 11800 nM
Compound 4: the middle estimate sits 1.1-fold (0.03 log units) below what was measured; the measured number falls inside the stated range.
By their numbers in this assay, from the lowest: compounds 1, 3 and 4 (each within the scatter of the next); then compound 2.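

In this assay, a 2-chlorophenyl on a double-bonded chain carbon bound to a double-bonded chain carbon stands level with the 4-methoxyphenyl, with a 1.5-fold higher number from compound 1 to compound 4 (0.18 log units; within the scatter), and level with the 4-nitrophenyl, with a 1.4-fold higher number from compound 3 to compound 4 (0.15 log units; within the scatter). Until now the 4-methoxyphenyl had been compared only with nitrophenyl groups; this result adds a ring that carries chlorine and has no hydrogen-bond acceptor, whereas the 4-methoxyphenyl has one, and the number stays within the scatter. Compound 2 also remains apart from this new compound, with a 2.1-fold lower number from compound 2 to compound 4 (0.32 log units; beyond the scatter), so among these four compounds the 3-nitrophenyl is the only group whose number is separated from the others.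

The data offer no measurement that explains why three of these rings stand level or why compound 2 differs. Every compound shown keeps a substituted phenyl at this place, so it remains open how the number would respond to a ring bearing an amine or a carboxylic acid, or to a longer chain in place of the ring.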